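Bromine for Fluorine on the Fused Ring of Compound 3

This account rests on a few compounds, and the source may have more. Where it says the series, first, only, none or still open, it means among the compounds named here.

Measured compounds in a functional assay on A549 cells (Homo sapiens) for cytotoxicity, with a stated time of 48 h; on this read-out higher numbers stand for weaker inhibition and lower numbers for stronger inhibition:
- compound 1, `CCCOc1ccc2oc(/C=C/[S+](C)[O-])cc(=O)c2c1`, 1100 nM
- compound 2, `CC(C)C(=O)Oc1ccc2oc(/C=C/[S+](C)[O-])cc(=O)c2c1`, 2400 nM
- compound 3, `C[S+]([O-])/C=C/c1cc(=O)c2cc(F)ccc2o1`, 2100 nM

Compound 3 sits second highest of the three numbers in this assay. Its nearest neighbour is compound 2, and the comparison a 1.1-fold lower number from compound 2 to compound 3 (0.06 log units; within the scatter) is within the scatter. Its furthest neighbour is compound 1, and the comparison a 1.9-fold higher number from compound 1 to compound 3 (0.28 log units; within the scatter) is also within the scatter. Only the move a 2.2-fold higher number from compound 1 to compound 2 (0.34 log units; beyond the scatter) is beyond the scatter, and that one concerns the oxygen-bound substituent rather than the position changed here. On these numbers compound 3 cannot be called either weaker or stronger than compound 1 or compound 2.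

Compound 4, `C[S+]([O-])/C=C/c1cc(=O)c2cc(Br)ccc2o1`, is not yet measured. It differs from compound 3 by bromo in place of fluoro on an aromatic carbon. Among the measured compounds shown here, no measured step exchanges one halogen for another, so the closest guide is the pair of steps into compound 3, both within the scatter, which suggests that this position tolerates change without large movement in this assay. Compound 4 is therefore expected to show a step of a 1.1-fold lower number from compound 3 to compound 4 (0.02 log units; within the scatter), that is, none beyond the scatter. Compound 4 is estimated at 2000 nM, with a range from 800 nM to 5000 nM.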

Compound 4, half-maximal inhibitory concentration: 1100 nM
Estimate against measurement, compound 4: 1.8-fold (0.26 log units) above; the measured number falls inside the stated range.
By their numbers in this assay, from the lowest: compounds 1, 4, 3 and 2 (each within the scatter of the next, the first and the last beyond it).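

In this assay, the exchange of bromo for fluoro on this aromatic carbon (a 1.9-fold lower number from compound 3 to compound 4 (0.28 log units; within the scatter)) is the only swap of one halogen for another among these compounds, and it cannot be told apart from the usual scatter, so the two halogens are not separated at this position. What compound 4 adds lies in its other two comparisons: bromo in place of (isopropylcarbonyl)oxy gives a modest step beyond the scatter (a 2.2-fold lower number from compound 2 to compound 4 (0.34 log units; beyond the scatter)), which compound 3 with its fluoro did not give, while bromo in place of propoxy leaves the number where it was (no change at the digits printed from compound 1 to compound 4 (within the scatter)), so at this position the bromo and propoxy compounds both stand apart from the ester compound 2, with the fluoro compound 3 as the exception that separates from neither side. No accompanying measurement offers an explanation for these numbers.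

The compounds shown leave open how chloro or iodo would read at this aromatic carbon, and whether an amine, a carboxylic acid or an alkoxy chain longer than propoxy would stay within the same narrow span. They also leave open whether the modest separation from compound 2 would hold in any cell line other than this one.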